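Swapping thiophen-2-yl for pyridin-4-yl on compound 3

The source may report more compounds than this note shows. Statements on the series, on what has been measured and on what is new or still open speak of the compounds shown alone.

In a functional assay on MES-SA/Dx5 cells (Homo sapiens) for inhibition, with a stated time of 72 h (on this read-out higher numbers stand for weaker inhibition and lower numbers for stronger inhibition), compound 1 `Oc1c(CN2CCCCC2)ccc2cccnc12` gives 850 nM; 832 nM (2 entries) as its value, with the several entries of compound 1 in this assay, 850 nM; 832 nM (2 entries) standing close together. Compound 2 `Oc1c(C(c2ccncc2)N2CCCC2)ccc2cccnc12` gives 3630 nM in this assay and compound 3 `Oc1c(C(c2cccs2)N2CCCCC2)ccc2cccnc12` gives 11500 nM there, which is the highest number shown. Its nearest neighbour is compound 2, on the lower side, and that gap lies beyond the usual scatter.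

Compound 4 `Oc1c(C(c2ccncc2)N2CCCCC2)ccc2cccnc12` has not yet been measured. It differs from compound 3 by pyridin-4-yl in place of thiophen-2-yl on a saturated chain carbon bound to an amine nitrogen in a ring and an aromatic carbon, a change counted as pyridin-4-yl in place of thiophen-2-yl on a saturated chain carbon bound to an amine nitrogen in a ring and an aromatic carbon in full. For the measured compounds named here, no measured pair isolates this swap, so any expectation is indirect. Compound 2 already carries pyridin-4-yl at that place, though with a different amine ring, and its value of 3630 nM offers the closest guide. The expected move is therefore towards stronger inhibition, an estimated 3.8-fold lower number from compound 3 to compound 4 (0.58 log units; beyond the scatter) in this assay that would lie beyond the scatter. For compound 4 the estimated value is 3000 nM, with an expected range from 1100 nM to 8000 nM until the measurement is known.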

Compound 4, half-maximal inhibitory concentration: 8320 nM
Estimate against measurement, compound 4: 2.8-fold (0.44 log units) below, and the stated range ends below it.
By their numbers in this assay, from the lowest: compound 2; then compounds 4 and 3 (each within the scatter of the next).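

In this assay, with the piperidin-1-yl ring held fixed, replacing thiophen-2-yl with pyridin-4-yl on the saturated chain carbon bound to an amine nitrogen in a ring and an aromatic carbon gives a 1.4-fold lower number from compound 3 to compound 4 (0.14 log units; within the scatter), so this read-out does not separate these two aromatic rings at this place. With pyridin-4-yl held fixed, the amine ring can now be read on its own, and piperidin-1-yl in place of pyrrolidin-1-yl gives a 2.3-fold higher number from compound 2 to compound 4 (0.36 log units; beyond the scatter), a modest step but the only one of the two that lies beyond the scatter. Nothing in the available evidence accounts for either step.

The compounds shown leave open whether a plain phenyl ring or pyridin-3-yl on this carbon would also fall within the scatter of these two aromatic rings, and how a morpholine ring in the amine's place would compare with piperidin-1-yl and pyrrolidin-1-yl. As far as these compounds go, only pyridin-4-yl is seen here with both amine rings, so it also remains open whether the amine step would hold with thiophen-2-yl on this carbon.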